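Triazole series: methylsulfanylphenyl in place of methoxyphenyl

The compounds below may be only part of what the source reports. "The series", "measured", "known", "first", "only" and "open" are said of these compounds alone.

Measured compounds:
compound 1 `COc1cccc(-c2ncnn2-c2cc(OC)c(OC)c(OC)c2)c1` — > 10000 nM in a functional assay on Jurkat cells (Homo sapiens) for antiproliferative activity, read by MTT assay, with a stated time of 72 h (on this read-out higher numbers stand for weaker inhibition and lower numbers for stronger inhibition), a limit of the assay
compound 2 `COc1cc(-c2ncnn2-c2ccc([N+](=O)[O-])cc2)cc(OC)c1OC` — > 10000 nM, a limit
compound 3 `CCOc1cccc(-c2ncnn2-c2cc(OC)c(OC)c(OC)c2)c1` — > 10000 nM, a limit

In this assay compound 1 sits only at the limit and gives no number. Going by the values given here, the same holds for compound 2 and for compound 3, so the series so far offers no measured value at all, only (the limit of > 10000 nM in this assay, at which 3 of the 3 values shown sit). Among the compounds with values here, the one step between measured compounds that differ in one place, a step that the two limits leave unreadable from compound 1 to compound 3, is therefore unreadable in size and direction, and compound 2 stands apart with no single-place partner.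

The compound still to be measured is compound 4 `COc1cc(-n2ncnc2-c2ccc(SC)cc2)cc(OC)c1OC`. It differs from compound 1 by 4-(methylsulfanyl)phenyl in place of 3-methoxyphenyl on an aromatic carbon.

Within the data shown here, no measured step bears on this change: the methyl-for-hydrogen step on the ether chain tells nothing, and no compound carrying a 4-(methylsulfanyl)phenyl group has been tested. With every value at the limit, the most defensible expectation is that compound 4 also stays at or near the limit, though a number below it cannot be excluded. Compound 4 is expected at 15000 nM, within 2000 nM to 60000 nM. The expected step that the limit leaves unreadable from compound 1 to compound 4 is accordingly set close to nothing beyond the scatter, with wide uncertainty.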

Compound 4, half-maximal inhibitory concentration: 50 nM
Beside the measured number, compound 4's estimate is 300-fold (2.48 log units) above it; measured number below the stated range.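

In this assay, going by these compounds alone, 4-(methylsulfanyl)phenyl in place of 3-methoxyphenyl on the aromatic carbon between two ring nitrogen atoms gives an at least 200-fold lower number from compound 1 to compound 4 (2.30 log units; beyond the scatter), the first readable step. This carbon therefore responds strongly to the choice of aromatic group, even though the two groups match in heavy atom count (8), in their one six-membered aromatic ring of carbon only and in hydrogen-bond acceptors (1). Compound 4 is the only compound here with a number, and the steps among the other compounds cannot be read, as they sit at a limit: the limit of > 10000 nM in this assay, at which 3 of the 4 values shown sit.

The step joins two changes, sulfur for oxygen and a different ring location of the substituent, and the compounds shown do not separate them; 4-methoxyphenyl and 3-(methylsulfanyl)phenyl would be the matching partners. Also open, as far as these compounds go, is how far the chain on the sulfur can be varied, for example with ethylsulfanyl, and whether a methylsulfonyl group in the same place would hold the number seen for compound 4.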